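Switching the hydroxycyclohexylamino group for a hydroxypiperidinyl group

This account rests on a few compounds, and the source may have more. Where it says the series, first, only, none or still open, it means among the compounds named here.

Among the three compounds measured so far, compound 3 `COc1cc[nH]c1/C=C1\C(=O)Nc2ccc([N+](=O)[O-])c(N[C@H]3CC[C@H](O)CC3)c21` stands highest in a functional assay on RKO cells (Homo sapiens) for antiproliferative activity, read by MTT assay, with a stated time of 5 days (a higher number here means a weaker inhibitor, a lower number a stronger inhibitor), at 8040 nM. Compound 1 `COc1cc[nH]c1/C=C1\C(=O)Nc2ccc([N+](=O)[O-])c(N3CC[C@H](O)C3)c21` gives 37 nM, and compound 2 `COc1cc[nH]c1/C=C1\C(=O)Nc2ccc([N+](=O)[O-])cc21` gives 692 nM. Both steps to compound 3 lie beyond the scatter: a 220-fold higher number from compound 1 to compound 3 (2.34 log units; beyond the scatter) and a 12-fold higher number from compound 2 to compound 3 (1.07 log units; beyond the scatter), so compound 3 is the least potent of the three.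

Compound 4 `COc1cc[nH]c1/C=C1\C(=O)Nc2ccc([N+](=O)[O-])c(N3CCC(O)CC3)c21` differs from compound 3 at one place: 4-hydroxypiperidin-1-yl in place of (4-hydroxycyclohexyl)amino on an aromatic carbon. For the measured compounds named here, two measured steps bear on this. The step of a 220-fold higher number from compound 1 to compound 3 (2.34 log units; beyond the scatter) shows that replacing the 3-hydroxypyrrolidin-1-yl of compound 1 by (4-hydroxycyclohexyl)amino costs a great deal, and the step of a 12-fold higher number from compound 2 to compound 3 (1.07 log units; beyond the scatter) shows that (4-hydroxycyclohexyl)amino in place of hydrogen also raises the number. The entering 4-hydroxypiperidin-1-yl resembles the group of compound 1 more than that of compound 3, so a large fall in the number is expected, roughly a 67-fold lower number from compound 3 to compound 4 (1.83 log units; beyond the scatter), though compound 1 remains the only comparable point. Compound 4 is therefore estimated at 120 nM, within 30 nM to 600 nM.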

Compound 4, half-maximal inhibitory concentration: < 10 nM
Compound 4: only a limit was reported; the forecaster's own chance of this, stated with the estimate: 0%; middle value at least 12-fold (1.07 log units) from the limit.
By their numbers in this assay, from the lowest: compound 1; then compound 2; then compound 3. At a limit, below all of these: compound 4.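

On the aromatic carbon ortho to a nitro group, a hydroxylated six-membered ring does not by itself decide the outcome: in this assay, 4-hydroxypiperidin-1-yl in place of (4-hydroxycyclohexyl)amino gives an at least 800-fold lower number from compound 3 to compound 4 (2.90 log units; beyond the scatter). In place of hydrogen the same group gives an at least 69-fold lower number from compound 2 to compound 4 (1.84 log units; beyond the scatter), and in place of 3-hydroxypyrrolidin-1-yl it gives an at least 3.7-fold lower number from compound 1 to compound 4 (0.56 log units; beyond the scatter), so among these compounds the groups joined through a ring nitrogen lower the number relative to hydrogen, while the amino-linked compound 3 goes against this. Compound 4 is reported only as a limit, so the steps to it have no fixed end: the limit of < 10 nM in this assay, at which 1 of the 4 values shown sits.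

The role of the hydroxyl remains open, as unsubstituted piperidine and morpholine are not among the compounds shown. From the compounds shown here alone, whether an open-chain amine such as dimethylamino or a piperazine would fit here also remains open.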